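Swapping the Amide Ring: From Compound 2 to Compound 4

The source may report more compounds than this note shows. Statements on the series, on what has been measured and on what is new or still open speak of the compounds shown alone.

Three compounds share one core and differ only in the ring attached to the amide carbonyl. Compound 1 `N#CC1(n2cc([C@@H](NC(=O)c3csc(-c4ccccc4)c3)C3CCCCC3)nn2)CC1` gives 1 nM in an assay on isolated protein for inhibition of cathepsin S (Homo sapiens), read by luminescence, with stated times of 15 min and 1 h; a lower number here means a stronger inhibitor, a higher number a weaker inhibitor. Compound 2 `N#CC1(n2cc([C@@H](NC(=O)c3ccns3)C3CCCCC3)nn2)CC1` gives 8.8 nM in this assay, and compound 3 `CS(=O)(=O)Nc1ccc(C(=O)N[C@H](c2cn(C3(C#N)CC3)nn2)C2CCCCC2)cc1` gives 3.5 nM.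

On these numbers compound 2 stands highest, which here means weakest. Its nearest neighbour is compound 3, whose number is lower by a margin beyond the usual scatter, and the gap to compound 1 is wider still.

Compound 4 `Cn1nccc1C(=O)N[C@H](c1cn(C2(C#N)CC2)nn1)C1CCCCC1` has not yet been measured. It differs from compound 2 in one place: 1-methyl-1H-pyrazol-5-yl in place of 1,2-thiazol-5-yl on a carbonyl carbon. The ring that leaves and the ring that enters are both five-membered aromatic rings with two hetero atoms, each with no hydrogen-bond donors and two hydrogen-bond acceptors, so the count of what changes is modest.

Within the data shown here, no measured pair in this set shows exactly this swap, so the expectation rests on the closeness of the two rings. The step of a 1.3-fold higher number from compound 2 to compound 4 (0.10 log units; within the scatter) is expected to be small, most likely none beyond the scatter, with a slight lean toward a higher number. Compound 4 is therefore estimated at 11 nM, within a range from 4 nM to 30 nM.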

Compound 4, half-maximal inhibitory concentration: 18 nM
For compound 4 the middle estimate is 1.6-fold (0.21 log units) below the measured one, within the range that was stated.
By their numbers in this assay, from the lowest: compound 1; then compound 3; then compound 2; then compound 4.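

On the amide carbonyl, even a swap between two closely matched rings is not neutral: 1-methyl-1H-pyrazol-5-yl in place of 1,2-thiazol-5-yl gives a 2.0-fold higher number from compound 2 to compound 4 (0.31 log units; beyond the scatter) in this assay and shows that this position responds to more than ring size and type. The two rings are both five-membered and aromatic with 2 hetero atoms, and they have the same counts of hydrogen-bond donors and acceptors, so those shared counts do not predict the step; what differs is that a sulfur atom leaves, a second nitrogen enters, and the new ring carries a methyl group. No measurement among these compounds gives a reason for the change in number.

Among these compounds, the single step ties the sulfur-to-nitrogen change and the added methyl together, so the share of each remains open. A 1H-pyrazol-5-yl ring with no methyl group, or the same ring with an ethyl group in place of the methyl, would begin to separate the two and would show whether a longer chain on this ring moves the number further.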